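This account rests on a few compounds, and the source may have more. Where it says the series, first, only, none or still open, it means among the compounds named here.

Compound 1 `CC1=C([Se]CC(OC(=O)[C@@H](CO)NC(=O)OC(C)(C)C)C(=O)NCCCCCC(=O)OCc2ccccc2)C(=O)c2ccccc2C1=O` and compound 2 `CC1=C([Se]CC(OC(=O)CNC(=O)OC(C)(C)C)C(=O)NCCCCCC(=O)OCc2ccccc2)C(=O)c2ccccc2C1=O` share the same core and differ only on the ester side: in a functional assay on MCF7 cells (Homo sapiens) for cytotoxicity, read by MTT assay, with a stated time of 24 h (on this read-out higher numbers stand for weaker inhibition and lower numbers for stronger inhibition), compound 1 gives 5000 nM, and compound 2 gives 4000 nM. The step of a 1.3-fold lower number from compound 1 to compound 2 (0.10 log units; within the scatter) shows that the two numbers sit within the scatter of each other, so compound 2 cannot be set apart from compound 1 on these figures; it is simply one of two values of similar size.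

Compound 3 `CC1=C([Se]CC(OC(=O)CC[Se]c2ccccc2)C(=O)NCCCCCC(=O)OCc2ccccc2)C(=O)c2ccccc2C1=O` is the next member, again altered on the ester side. The change from compound 2 is a group of 8 heavy atoms (7 carbon, 1 selenium; one six-membered aromatic ring of carbon only) in place of a group of 8 heavy atoms (5 carbon, 1 nitrogen, 2 oxygen; no ring), on a saturated chain carbon bound to a carbonyl carbon. Among the compounds with values here, no measured step covers an exchange of this kind; the only step known, a 1.3-fold lower number from compound 1 to compound 2 (0.10 log units; within the scatter), is a small alteration in the same region that did not move the number beyond the scatter. With nothing in the two measured compounds pointing to a large shift, the expectation for this assay is a step of about a 1.3-fold lower number from compound 2 to compound 3 (0.12 log units; within the scatter) from compound 2 to compound 3, not beyond the scatter. The estimate for compound 3 is 3000 nM, with a range of 1000 nM to 10000 nM.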

Compound 3, half-maximal inhibitory concentration: 9000 nM
For compound 3 the middle estimate is 3.0-fold (0.48 log units) below the measured one; measured number inside the range.
By their numbers in this assay, from the lowest: compounds 2, 1 and 3 (each within the scatter of the next, the first and the last beyond it).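

In this assay, within the data shown here, the group of selenium and a six-membered aromatic ring of carbon only, in place of (tert-butoxycarbonyl)amino on a saturated chain carbon bound to a carbonyl carbon, gives a 2.3-fold higher number from compound 2 to compound 3 (0.35 log units; beyond the scatter), a modest move and the one step printed as beyond the scatter, so the number at this position does respond to the group carried there, which the exchange of hydroxymethyl for hydrogen did not show. The separation holds only against compound 2, since the comparison with the larger group on the carbonyl carbon reads a 1.8-fold higher number from compound 1 to compound 3 (0.26 log units; within the scatter) and leaves those two compounds within the scatter of each other. No measurement at hand bears on the reason for the step.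

The selenium and the aromatic ring enter together, so these compounds do not tell which of the two carries the step, and a sulfur atom in place of the selenium would separate them. Going by these compounds, how a free amine or a carboxylic acid on the same saturated chain carbon would read also remains open.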